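The source may report more compounds than this note shows. Statements on the series, on what has been measured and on what is new or still open speak of the compounds shown alone.

Measured in a functional assay on A549 cells (Homo sapiens) for antiproliferative activity, read by MTT assay, with a stated time of 48 h; a lower number here means a stronger inhibitor, a higher number a weaker inhibitor:
- compound 1 `COc1cc(/C=C/c2nnc(NC(=O)c3ccccc3Br)s2)c(Br)c(OC)c1OC`: 210 nM
- compound 2 `COc1cc(/C=C/c2nnc(NC(=O)c3cccc(F)c3)s2)c(Br)c(OC)c1OC`: 80 nM
- compound 3 `COc1cc(/C=C/c2nnc(NC(=O)c3cccc(O)c3)s2)c(Br)c(OC)c1OC`: 120 nM

Compound 3 falls inside the span set by the other two, and neither of its steps leaves the scatter: a 1.8-fold lower number from compound 1 to compound 3 (0.24 log units; within the scatter), and a 1.5-fold higher number from compound 2 to compound 3 (0.18 log units; within the scatter). The next compound, compound 4 `COc1cc(/C=C/c2nnc(NC(=O)c3ccccc3)s2)c(Br)c(OC)c1OC`, has hydrogen in place of hydroxy on an aromatic carbon, which turns the 3-hydroxyphenyl into phenyl.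

Among the compounds with values here, no measured compound carries the plain phenyl, so the removal of a substituent has not been tested directly. The closest evidence is the exchange of fluoro for hydroxy on the same carbon, a 1.5-fold higher number from compound 2 to compound 3 (0.18 log units; within the scatter), which stays within the scatter. The largest step in the set, a 2.6-fold lower number from compound 1 to compound 2 (0.42 log units; beyond the scatter), is modest and goes beyond the scatter, but it exchanges one substituted aromatic group for another, so it bears on compound 4 only loosely. It does show that changes at this end of the molecule have so far moved this assay only slightly.

The expected change is small, with no clear direction: a 1.2-fold higher number from compound 3 to compound 4 (0.07 log units; within the scatter), an estimated step not expected to exceed the scatter. The estimated value for compound 4 is 140 nM, with an expected range from 65 nM to 300 nM.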

Compound 4, half-maximal inhibitory concentration: 110 nM
The estimate for compound 4 lay 1.3-fold (0.10 log units) above the measured number; the measured number falls inside the stated range.
By their numbers in this assay, from the lowest: compounds 2, 4, 3 and 1 (each within the scatter of the next, the first and the last beyond it).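

With the plain phenyl in hand, the aromatic ring at this end of the molecule can be read without any substituent: in this assay, hydrogen in place of hydroxy gives a step within the scatter (a 1.1-fold lower number from compound 3 to compound 4 (0.04 log units; within the scatter)), as do hydrogen in place of fluoro (a 1.4-fold higher number from compound 2 to compound 4 (0.14 log units; within the scatter)) and hydrogen in place of bromo (a 1.9-fold lower number from compound 1 to compound 4 (0.28 log units; within the scatter)). Among these compounds, then, none of the three substituents is needed to keep the number in this range, and the hydrogen-bond donor and acceptor counted on the hydroxy can leave without a step beyond the scatter. Compound 4 lies within the scatter of both compound 1 and compound 2, so neither fluoro nor bromo can be said to differ from hydrogen here, and no measurement on hand accounts for these numbers.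

From the compounds shown here alone, whether a group of another kind on this ring, such as an amine, a carboxylic acid or a longer alkoxy chain, would produce a step beyond the scatter stays open. Also open, going by these compounds, is whether the phenyl can be exchanged for a saturated ring or an open alkyl chain while the number stays in this range.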